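Adding Chloro to the Phenyl Ring of Compound 2

This account rests on a few compounds, and the source may have more. Where it says the series, first, only, none or still open, it means among the compounds named here.

Of the compounds shown here, three sharing a core have been measured in a functional assay on CaEs17 cells (Homo sapiens) for cytotoxicity, read by MTT assay, with a stated time of 72 h; a lower number here means a stronger inhibitor, a higher number a weaker inhibitor. Compound 1 (`C=C1C(=O)[C@@]23C(=O)OC[C@]4(C(=O)CCC(C)(C)[C@H]4C=O)[C@@H]2CC[C@@H]1[C@H]3OC(=O)CC`), with an ethyl on the carbonyl carbon of its side chain, gives 1400 nM. Compound 2 (`C=C1C(=O)[C@@]23C(=O)OC[C@]4(C(=O)CCC(C)(C)[C@H]4C=O)[C@@H]2CC[C@@H]1[C@H]3OC(=O)c1ccccc1`), with a phenyl there, gives 1710 nM. The result is a 1.2-fold higher number from compound 1 to compound 2 (0.09 log units; within the scatter), so compound 2 stands level with compound 1. Compound 3 (`C=C1C(=O)[C@@]23C(=O)OC[C@]4(C(=O)CCC(C)(C)[C@H]4C=O)[C@@H]2CC[C@@H]1[C@H]3OC(=O)c1ccc(F)cc1`), the 4-fluorophenyl counterpart, gives 8310 nM, which leaves compound 2 clearly the stronger of that pair.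

Compound 4 (`C=C1C(=O)[C@@]23C(=O)OC[C@]4(C(=O)CCC(C)(C)[C@H]4C=O)[C@@H]2CC[C@@H]1[C@H]3OC(=O)c1ccccc1Cl`) departs from compound 2 in one place, with chloro in place of hydrogen on an aromatic carbon, ortho to a large group (chloro in place of hydrogen on an aromatic carbon). The closest guide is a 4.9-fold higher number from compound 2 to compound 3 (0.69 log units; beyond the scatter), where fluoro replaces hydrogen on the same kind of ring. The comparison a 5.9-fold higher number from compound 1 to compound 3 (0.77 log units; beyond the scatter) points the same way. That is a single precedent, with a different halogen at a different place, so it supports only a cautious expectation of a weaker compound, and a result within the scatter remains possible. The expected change in this assay is a 1.9-fold higher number from compound 2 to compound 4 (0.27 log units; within the scatter). Compound 4 is estimated at 3200 nM, with an expected range of 1100 nM to 9000 nM.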

Compound 4, half-maximal inhibitory concentration: 2010 nM
Estimate against measurement, compound 4: 1.6-fold (0.20 log units) above; measured number inside the range.
By their numbers in this assay, from the lowest: compounds 1, 2 and 4 (each within the scatter of the next); then compound 3.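

In this assay, chloro ortho to a large group on the phenyl ring leaves compound 4 level with its parent, at a 1.2-fold higher number from compound 2 to compound 4 (0.07 log units; within the scatter), which shows that a halogen on this ring does not always come with a weaker compound; compound 3 is the one case among these that does. Compound 4 also stands level with the ethyl compound, at a 1.4-fold higher number from compound 1 to compound 4 (0.16 log units; within the scatter), yet it is clearly the stronger against the fluoro compound, at a 4.1-fold lower number from compound 3 to compound 4 (0.62 log units; beyond the scatter), so among the four only compound 3 stands apart from the others. No measurement shown here bears on why this halogen and this place behave as they do.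

Compound 3 and compound 4 differ in both the halogen and its place on the ring, so these compounds cannot tell which of the two matters; a 4-chlorophenyl or a 2-fluorophenyl group would separate them. From the compounds shown here alone, how a ring substituent other than a halogen, such as a methoxy group or an amine, would read in this assay also remains open.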